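The source may hold more compounds than are shown below. What is called first, only, known or untested is meant among the compounds shown, and "the series" means these compounds.

Working notes on the series. Going by the values given here, in a functional assay on KB cells (Homo sapiens) for antiproliferative activity, read by sulforhodamine B assay, with a stated time of 3 days (on this read-out higher numbers stand for an effect only at larger amounts of compound and lower numbers for an effect already at smaller amounts), compound 2 `CCC1=C(O)c2c(oc(-c3ccc(C(C)C)cc3)cc2=O)C(CC)(CC)C1=O` gives 8.13 uM, and this is the only plain number among the three values shown. Compound 1 `CCC1=C(O)c2c(oc(-c3ccccc3)cc2=O)C(CC)(CC)C1=O` is reported at a limit of this assay, > 236 uM, as recorded in the limit of > 236 uM in this assay, at which 1 of the 3 values shown sits. Compound 3 `CCOc1ccc(-c2cc(=O)c3c(o2)C(CC)(CC)C(=O)C(CC)=C3O)cc1` is also reported at a limit, > 52.4 uM, as recorded in the limit of > 52.4 uM in this assay, at which 1 of the 3 values shown sits.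

Compound 4 `CCC1=C(O)c2c(oc(-c3cccc(OC)c3)cc2=O)C(CC)(CC)C1=O` has not yet been run in this assay. Its change from compound 2: 3-methoxyphenyl in place of 4-isopropylphenyl on an aromatic carbon. Among the compounds with values here, two measured steps bear on it. Introducing isopropyl produced an at least 29-fold lower number from compound 1 to compound 2 (1.46 log units; beyond the scatter), while exchanging isopropyl for an alkoxy group produced an at least 6.4-fold higher number from compound 2 to compound 3 (0.80 log units; beyond the scatter); the remaining comparison, a step that the two limits leave unreadable from compound 1 to compound 3, adds nothing readable. Removing the isopropyl in favour of a methoxy is therefore expected to give a higher number in this assay, plausibly reaching a limit again. Compound 4 is estimated at 60 uM, within 15 uM to 240 uM, an expected step of a 7.4-fold higher number from compound 2 to compound 4 (0.87 log units; beyond the scatter).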

Compound 4, concentration for half-maximal effect: 13.3 uM
Beside the measured number, compound 4's estimate is 4.5-fold (0.65 log units) above it, outside the stated range (below it).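

In this assay, replacing 4-isopropylphenyl with 3-methoxyphenyl gives a 1.6-fold higher number from compound 2 to compound 4 (0.21 log units; within the scatter), so at this position the two groups cannot be told apart, and the isopropyl group is not the only substituent that gives a measurable value. Methoxy in place of hydrogen gives an at least 17-fold lower number from compound 1 to compound 4 (1.24 log units; beyond the scatter), a large step of the same kind as that seen with isopropyl, so the unsubstituted phenyl is no longer the only comparison pointing to a gain from substitution. An alkoxy group as such therefore does not carry the poorer result of compound 3, as 3-methoxyphenyl in place of 4-ethoxyphenyl gives an at least 3.9-fold lower number from compound 3 to compound 4 (0.59 log units; beyond the scatter).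

That step changes both the chain and its place on the phenyl ring, so the compounds shown do not separate the two. As far as these compounds go, how an amine, a carboxylic acid or a longer chain such as butoxy would behave on this ring remains open.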